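Bromo for chloro on the shared core

The compounds below may be only part of what the source reports. "The series", "measured", "known", "first", "only" and "open" are said of these compounds alone.

Measured in a functional assay on HCC 2998 cells (Homo sapiens) for antiproliferative activity; on this read-out lower numbers stand for stronger inhibition of growth and higher numbers for weaker inhibition of growth:
- compound 1 `COc1ccc(-c2nc3ccccc3s2)cc1OC`: 42500 nM
- compound 2 `COc1ccc(-c2nc3cc(Cl)ccc3s2)cc1OC`: 4880 nM

Of the two measured compounds, compound 2 holds the lower number, at 4880 nM. The next compound, compound 3 `COc1ccc(-c2nc3cc(Br)ccc3s2)cc1OC`, carries bromo in place of chloro on an aromatic carbon. Going by the values given here, one measured step bears on this change: an 8.7-fold lower number from compound 1 to compound 2 (0.94 log units; beyond the scatter), with chloro in place of hydrogen on an aromatic carbon. Among the compounds with values here, that step lies beyond the scatter, but it starts from hydrogen, and no measurement yet compares one of these two groups directly with the other. With compound 2 at 4880 nM as the anchor, no step beyond the scatter is expected in this assay, and no direction is favoured. The expected step is a 1.1-fold lower number from compound 2 to compound 3 (0.04 log units; within the scatter). For compound 3 the estimated value is 4500 nM, with an expected range of 1800 nM to 11000 nM.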

Compound 3, concentration for 50% growth inhibition: 20000 nM
Compound 3: the middle estimate sits 4.4-fold (0.65 log units) below what was measured; measured number above the stated range.
By their numbers in this assay, from the lowest: compound 2; then compound 3; then compound 1.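

In this assay, going by these compounds alone, the two halogens are not interchangeable at this position: the first direct comparison of chloro and bromo on the shared core gives a 4.1-fold higher number from compound 2 to compound 3 (0.61 log units; beyond the scatter) and so separates groups that the earlier pair could not. Bromo keeps only part of the drop seen with chloro, with a 2.1-fold lower number from compound 1 to compound 3 (0.33 log units; beyond the scatter) still printed as beyond the scatter. Both halogens therefore give lower numbers than hydrogen here, and chloro gives the lowest of the three. Nothing available explains the gap between the two halogens.

On these data alone, whether fluoro, methyl or an amine on this same aromatic carbon would fall nearer to chloro or to hydrogen remains open. Also open, as far as these compounds go, is whether chloro keeps its lead over bromo with the two methoxy groups of the shared core replaced.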